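Weighing a Trimethylphenyl Analogue Against Its Measured Precursor

The source may report more compounds than this note shows. Statements on the series, on what has been measured and on what is new or still open speak of the compounds shown alone.

In a functional assay on HepG2 cells (Homo sapiens) for antiproliferative activity, read by MTT assay, with a stated time of 48 h (a lower number here means a stronger inhibitor, a higher number a weaker inhibitor), compound 2 `N#CC1=C(N)Oc2c(N)cc3nc4ccccc4nc3c2C12C(=O)N(Cc1cnnn1-c1cccc(C(F)(F)F)c1)c1ccccc12` gives 15800 nM. Compound 1 `Cc1cccc(-n2nncc2CN2C(=O)C3(C(C#N)=C(N)Oc4c3c3nc5ccccc5nc3c3ccccc43)c3ccccc32)c1` reaches only the limit > 50000 nM in this assay. Compound 2 thus stands as the single measured number shown, the other value being a limit (the limit of > 50000 nM in this assay, at which 1 of the 2 values shown sits). Compound 3 `Cc1cc(C)c(-n2nncc2CN2C(=O)C3(C(C#N)=C(N)Oc4c(N)cc5nc6ccccc6nc5c43)c3ccccc32)c(C)c1` differs from compound 2 by 2,4,6-trimethylphenyl in place of 3-(trifluoromethyl)phenyl on an aromatic nitrogen. Within the data shown here, no measured step of this kind is available among the compounds, so the expected step of a 1.3-fold higher number from compound 2 to compound 3 (0.10 log units; within the scatter) is taken as small, within the usual scatter or leaning slightly toward a weaker inhibitor. Compound 3 is accordingly estimated at 20000 nM, with a range from 7000 nM to 60000 nM.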

Compound 3, half-maximal inhibitory concentration: 48100 nM
Estimate against measurement, compound 3: 2.4-fold (0.38 log units) below; measured number inside the range.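

In this assay, this position proves sensitive to the aryl group: 2,4,6-trimethylphenyl in place of 3-(trifluoromethyl)phenyl on an aromatic nitrogen gives a 3.0-fold higher number from compound 2 to compound 3 (0.48 log units; beyond the scatter). The earlier compounds shown here offered no measured step of any kind. Compound 1 still adds no comparison, as its value is a limit and not a number: the limit of > 50000 nM in this assay, at which 1 of the 3 values shown sits.

Going by these compounds, whether the step comes from losing 3-(trifluoromethyl)phenyl or from gaining 2,4,6-trimethylphenyl stays open. Also open, on these data alone, is how a phenyl carrying an amine or a carboxylic acid would read at this position.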